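Adding a Third Methoxy Group to the Fused Ring

A few compounds are considered here, and "the series" means these few. Any claim that something is new, unique, unknown or untested is made for them only; others in the source may bear on it.

Measured compounds:
Compound 1, `COc1cc2c(cc1OC)CN(CCCCCCC(=O)c1c(C)c(OC)c(OC)c(OC)c1OC)CC2`, 1.33 nM
Compound 2, `COc1cc2c(c(OC)c1OC)CCN(CCCCCCC(=O)c1c(C)c(OC)c(OC)c(OC)c1OC)C2`, 40 nM

Both compounds were tested in an assay on membranes from liver for displacement of a labelled ligand from Sigma intracellular receptor 2 (Rattus norvegicus), read by scintillation counting, with a stated time of 120 min; a lower number here means a stronger inhibitor, a higher number a weaker inhibitor. Compound 1 stands at the lowest of the two numbers; its nearest neighbour is compound 2, and the step is a 30-fold higher number from compound 1 to compound 2 (1.48 log units; beyond the scatter). Compound 3, `COc1cc2c(c(OC)c1OC)CN(CCCCCCC(=O)c1c(C)c(OC)c(OC)c(OC)c1OC)CC2`, has not yet been measured. It differs from compound 1 by methoxy in place of hydrogen on an aromatic carbon. Among the measured compounds shown here, the one measured step that bears on this change is the one a 30-fold higher number from compound 1 to compound 2 (1.48 log units; beyond the scatter), where the same kind of group enters on the same sort of aromatic carbon, and it was large. Compound 3 is therefore expected to give a clearly higher number than compound 1, a step estimated at a 19-fold higher number from compound 1 to compound 3 (1.27 log units; beyond the scatter). The estimate for compound 3 is 25 nM, with a range from 6 nM to 100 nM.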

Compound 3, inhibition constant: > 1000 nM
Compound 3 was reported as a limit; the forecaster's own chance of this, stated with the estimate: 2%; middle value at least 40-fold (1.60 log units) away from the limit.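

In this assay compound 3 gives > 1000 nM, which is a limit of the assay and not a number. Methoxy in place of hydrogen on this aromatic carbon, ortho to a methoxy group, gives an at least 750-fold higher number from compound 1 to compound 3 (2.87 log units; beyond the scatter), whereas the earlier step of the same kind was a 30-fold higher number from compound 1 to compound 2 (1.48 log units; beyond the scatter), so this change does not have one fixed size on the core of compound 1. The step to compound 3 is bounded on one side only, and its full size cannot be read from a value resting on this: the limit of > 1000 nM in this assay, at which 1 of the 3 values shown sits.

From the compounds shown here alone, what a fluorine or a hydroxyl on this aromatic carbon would give in this assay remains open. The compounds shown also do not tell why the added methoxy has so large an effect here.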